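The compounds below may be only part of what the source reports. "The series", "measured", "known", "first", "only" and "open" are said of these compounds alone.

Compound 3 `C[C@H](Nc1ncnc(N)c1C#N)c1cc(=O)n2cc(F)ccc2c1-c1ccccc1` gives the higher of the two numbers recorded in an ADME assay on microsomes from liver (Homo sapiens), read by LC-MS, using NADPH, with a stated time of 30 min, tested at 1 uM (on this read-out higher numbers stand for a more stable compound and lower numbers for a less stable compound), namely 90%. Its nearest neighbour on this read-out is compound 1 `Cc1cccc2cc([C@H](C)Nc3ncnc4[nH]cnc34)c(-c3ccccc3)c(=O)n12`, which in this assay gives 70%, a result that stands lower than compound 3 by a gap beyond the scatter. A third compound, compound 2 `C[C@H](Nc1nc(N)nc(N)c1C#N)c1cc(=O)n2cc(F)ccc2c1-c1ccccc1`, was run without a reported number: in this assay compound 2 gives "not determined" (no result reported). Among the compounds with values here, no step between measured compounds that differ in one place is available, so nothing in the measured set shows how a change of the kind leading to compound 4 behaves.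

Compound 4 `C[C@H](Nc1ncnc(N)c1C#N)c1cc(=O)n2cc(F)ccc2c1-c1cc(F)cc(F)c1` differs from compound 3 in one place: 3,5-difluorophenyl in place of phenyl on an aromatic carbon. With compound 3 already high at 90%, compound 4 is expected to stay close to it, with any step from compound 3 to compound 4 of a number 5 percentage points lower from compound 3 to compound 4 (within the scatter) judged as lying within the scatter rather than beyond it. In this assay compound 4 is therefore estimated at 85%, with a range from 65% to 97%.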

Compound 4, percent of the compound remaining: 91%
The estimate for compound 4 lay 6 percentage points below the measured number; measured number inside the range.
By their numbers in this assay, from the lowest: compound 1; then compounds 3 and 4 (each within the scatter of the next).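

Within the data shown here, the first step in this set between compounds that differ in one place concerns the phenyl on an aromatic carbon, ortho to a fused ring: in this assay, 3,5-difluorophenyl in its place gives a number 1 percentage points higher from compound 3 to compound 4 (within the scatter). At this position, then, the larger ring substituent with its two fluorine atoms brings no step beyond the scatter, a finding that rests on this single pair and on this one core. No measurement shown here explains this result.

On these data alone, it remains open how other groups would read at this position, such as a single fluorine on the phenyl, a methoxy group on the phenyl, or a pyridyl ring in its place. As far as these compounds go, it is also open whether 3,5-difluorophenyl would behave alike on the core of compound 1, which carries the same phenyl.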